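The source may report more compounds than this note shows. Statements on the series, on what has been measured and on what is new or still open speak of the compounds shown alone.

Compound 1, `Cc1ccc(N2CCN(C(=O)[C@@H]3CN(C4CCOCC4)C[C@H]3c3ccc(Cl)cc3)CC2)c([C@@H](NC(=O)CN)C(C)C)c1`, gives 114% in a functional assay on CHO cells with Melanocortin receptor 4 (Homo sapiens) as the target, read by cAMP accumulation; a higher number here means a larger maximal response, a lower number a smaller maximal response. Compound 2, `CC(C)[C@H](NC(=O)CCN(C)C)c1cccc(F)c1N1CCN(C(=O)[C@@H]2CN(C(C)C)C[C@H]2c2ccc(Cl)cc2)CC1`, gives 103% in this assay. Compound 3, `CC(C)[C@H](NC(=O)CCN(C)C)c1cccc(F)c1N1CCN(C(=O)[C@@H]2CN(C(C)C)C[C@H]2c2ccc(F)c(Cl)c2)CC1`, gives 78% in this assay.

Among these three, compound 3 stands lowest in this assay. Its nearest neighbour is compound 2, whose number lies above it beyond the scatter, and the furthest is compound 1, higher still. Within the data shown here, the one step that joins two measured compounds differing in a single place runs a number 25 percentage points lower from compound 2 to compound 3 (beyond the scatter), where a 3-chloro-4-fluorophenyl group replaced a 4-chlorophenyl group on a saturated ring carbon.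

Compound 4, `CC(C)[C@H](NC(=O)CCN(C)C)c1cccc(F)c1N1CCN(C(=O)[C@@H]2CN(C(C)C)C[C@H]2c2ccc(C(F)(F)F)c(F)c2)CC1`, is the next step from compound 3: 3-fluoro-4-(trifluoromethyl)phenyl in place of 3-chloro-4-fluorophenyl on a saturated ring carbon. This change sits at the same saturated ring carbon as the change from compound 2 to compound 3, so that step is the one that bears on it; it was a modest drop, beyond the scatter. Among the measured compounds shown here, with only one such step to go on, a further modest loss or no change beyond the scatter both seem possible, and the expectation leans toward a small decline. Compound 4 is therefore expected to give 68% in this assay, within a range from 45% to 92%, which amounts to an expected step of a number 10 percentage points lower from compound 3 to compound 4 (within the scatter).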

Compound 4, intrinsic activity: the largest response reached, in percent of the reference agonist's: 47%
Compound 4: middle estimate off by 21 percentage points, on the high side, within the range that was stated.
By their numbers in this assay, from the lowest: compound 4; then compound 3; then compound 2; then compound 1.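

The substituents on the phenyl ring at this saturated ring carbon of the five-membered non-aromatic ring with 1 nitrogen now show a second and larger effect on maximal response: in this assay, replacing 3-chloro-4-fluorophenyl with 3-fluoro-4-(trifluoromethyl)phenyl gives a number 31 percentage points lower from compound 3 to compound 4 (beyond the scatter), although the phenyl ring is kept and the counted hydrogen-bond donors, acceptors and net charge stay the same. Measured against the 4-chlorophenyl group, the change amounts to a number 56 percentage points lower from compound 2 to compound 4 (beyond the scatter), so both substituted groups shown at this carbon fall below the 4-chlorophenyl compound, and neither step from it goes against that pattern. No measurement is available here to explain this loss of response.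

The two groups differ from each other in both of their substituents, so these compounds cannot separate the effect of removing chlorine from that of adding trifluoromethyl, or show which substituent governs the response. Going by these compounds, a 4-(trifluoromethyl)phenyl or 4-methoxyphenyl group at this carbon would leave a single difference from the 4-chlorophenyl compound, and what either would do to the response in this assay remains open.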